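The source may hold more compounds than are shown below. What is called first, only, known or untested is meant among the compounds shown, and "the series" means these compounds.

In a functional assay (aorta) for inhibition, with Rattus norvegicus as the target (a lower number here means a stronger inhibitor, a higher number a weaker inhibitor), compound 1 `CCC/N=C(\S)[C@]1(c2cccnc2)CCCC[S+]1[O-]` gives 600 nM. Compound 2 `[O-][S+]1CCCC[C@]1(CO)c1cccnc1` gives > 30000 nM, which is a limit of the assay and not a number. Within the data shown here, the one measured step that bears on the next change is large and beyond the scatter: an at least 50-fold higher number from compound 1 to compound 2 (1.69 log units; beyond the scatter). It replaced a whole group on the saturated ring carbon and shows that activity can be lost there, but it does not isolate the effect of any single atom.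

Compound 3 `[O-][S+]1CCCC[C@]1(CS)c1cccnc1` has sulfanyl in place of hydroxy on a saturated chain carbon bound to a saturated ring carbon. Among the measured compounds shown here, no measured step tests this exchange alone, so only a modest recovery of the loss seen in an at least 50-fold higher number from compound 1 to compound 2 (1.69 log units; beyond the scatter) is expected. In this assay, the expected change is an at least 1.5-fold lower number from compound 2 to compound 3 (0.17 log units; that floor lies within the scatter), towards a lower number. Compound 3 is estimated at 20000 nM, with an expected range of 3000 nM to 60000 nM.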

Compound 3, concentration for 90% inhibition: > 30000 nM
Compound 3 ended at the assay's limit; the forecaster's own chance of this, stated with the estimate: 50%; middle value at least 1.5-fold (0.17 log units) from the limit.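

In this assay compound 3 gives > 30000 nM, which is a limit of the assay and not a number. Sulfanyl in place of hydroxy does not bring back a measurable value, and the step between compound 2 and compound 3 cannot be read, because both compounds sit at the same limit: the limit of > 30000 nM in this assay, at which 2 of the 3 values shown sit. The loss on the saturated ring carbon now holds for a second short group, sulfanylmethyl as well as hydroxymethyl, with an at least 50-fold higher number from compound 1 to compound 3 (1.69 log units; beyond the scatter).

Hydroxymethyl and sulfanylmethyl therefore cannot be ranked against each other, and which part of the larger group in compound 1 is needed for its activity stays open. Also open, as far as these compounds go, is whether an amine, a carboxylic acid or a longer chain on the same saturated ring carbon would give a measurable value.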